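Cyano in Place of Chloro on the Benzyl Ring

This account rests on a few compounds, and the source may have more. Where it says the series, first, only, none or still open, it means among the compounds named here.

Measured compounds:
compound 1 `N#Cc1ccc(Nc2nccc(OCc3cccc(Cl)c3)n2)cc1` – 153000 nM
compound 2 `Cc1ccc(COc2ccnc(Nc3ccc(C#N)cc3)n2)cc1` – 81000 nM
compound 3 `COc1cccc(COc2ccnc(Nc3ccc(C#N)cc3)n2)c1` – 118000 nM

In an ADME assay on MT4 cells (Homo sapiens) for cytotoxicity, read by MTT assay, with a stated time of 5 days (on this read-out higher numbers stand for lower toxicity in this test and lower numbers for higher toxicity in this test), compound 1 gives the highest of the three numbers, but all three lie within the scatter of one another: a 1.3-fold lower number from compound 1 to compound 3 (0.11 log units; within the scatter) and a 1.9-fold lower number from compound 1 to compound 2 (0.28 log units; within the scatter), and likewise a 1.5-fold higher number from compound 2 to compound 3 (0.16 log units; within the scatter). Compound 4 `N#Cc1ccc(Nc2nccc(OCc3cccc(C#N)c3)n2)cc1` is compound 1 with cyano in place of chloro on an aromatic carbon. The step that bears most directly on it is the exchange at the same aromatic carbon, a 1.3-fold lower number from compound 1 to compound 3 (0.11 log units; within the scatter), and the wider exchanges of the whole benzyl group also stayed within the scatter. Compound 4 is therefore expected to show no step beyond the scatter, a 1.1-fold lower number from compound 1 to compound 4 (0.04 log units; within the scatter). The estimate for compound 4 is 140000 nM, with a range from 70000 nM to 280000 nM.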

Compound 4, half-maximal cytotoxic concentration: 4100 nM
Compound 4: the middle estimate sits 34-fold (1.53 log units) above what was measured; the measured number lies below the stated range.
By their numbers in this assay, from the lowest: compound 4; then compounds 2, 3 and 1 (each within the scatter of the next).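

In this assay, going by these compounds alone, this aromatic carbon of the benzyl ring proved far more sensitive to its substituent than the earlier compounds suggested: cyano in place of chloro gives a 37-fold lower number from compound 1 to compound 4 (1.57 log units; beyond the scatter), and cyano in place of methoxy gives a 29-fold lower number from compound 3 to compound 4 (1.46 log units; beyond the scatter), although chloro and methoxy there lie within the scatter of each other. The 3-cyanophenyl group also stands apart from 4-methylphenyl, with a 20-fold lower number from compound 2 to compound 4 (1.30 log units; beyond the scatter). Nothing measured here explains these steps. As far as these compounds go, what an amine or a carboxylic acid on this aromatic carbon would give remains open, as does whether the cyano step holds on a different core.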